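Compound 2 leads before the nitrile change

The compounds below may be only part of what the source reports. "The series", "measured", "known", "first", "only" and "open" are said of these compounds alone.

Compound 1 `COc1cccc(Nc2nc(Nc3cc(C)[nH]n3)cc(N3CCN(C)CC3)n2)c1`: 1690 nM
Compound 2 `Cc1cc(Nc2cc(N3CCN(C)CC3)nc(Nc3cccc(Cl)c3)n2)n[nH]1`: 723 nM

Going by the values given here, in a functional assay on A549 cells (Homo sapiens) for antiproliferative activity, read by CCK-8 assay, with a stated time of 72 h (on this read-out lower numbers stand for stronger inhibition and higher numbers for weaker inhibition), compound 2 gives 723 nM, the lower of the two numbers measured so far. The next compound to be tested is compound 3 `Cc1cc(Nc2cc(N3CCN(C)CC3)nc(Nc3ccc(C#N)cc3)n2)n[nH]1`, which keeps the shared core and has 4-cyanophenyl in place of 3-chlorophenyl on a nitrogen on an aromatic ring. Among the compounds with values here, only one measured step bears on this change, and only loosely. It is a 2.3-fold lower number from compound 1 to compound 2 (0.37 log units; beyond the scatter), a modest move with chloro in place of methoxy on an aromatic carbon. Within the data shown here, no measured compound carries a nitrile, and the data do not settle the direction of the coming step. On the size of that single step from compound 1 to compound 2, a step of similar or smaller size is expected in this assay, leaning slightly towards a higher number. The expected result is a 1.3-fold higher number from compound 2 to compound 3 (0.12 log units; within the scatter). For compound 3 the estimated value is 950 nM, with an expected range from 320 nM to 2800 nM.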

Compound 3, half-maximal inhibitory concentration: 785 nM
Compound 3: the middle estimate sits 1.2-fold (0.08 log units) above what was measured; measured number inside the range.
By their numbers in this assay, from the lowest: compounds 2 and 3 (each within the scatter of the next); then compound 1.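

In this assay, the position on a nitrogen on an aromatic ring accepts a second, quite different substituted phenyl without any clear shift: the change to 4-cyanophenyl gives a 1.1-fold higher number from compound 2 to compound 3 (0.04 log units; within the scatter) and so does not separate the two compounds. Set against the 3-methoxyphenyl group, the same 4-cyanophenyl group gives a 2.2-fold lower number from compound 1 to compound 3 (0.33 log units; beyond the scatter) in a modest step that closely matches the earlier gain seen with chloro, which leaves compound 1 as the only one of the three clearly apart from the others. No measurement shown here offers an explanation for these numbers or for why a nitrile and a chloro group end up level at this position.

Compound 3 differs from compound 2 in both the group on the phenyl ring and where that group sits, so the two contributions cannot be told apart, and 3-cyanophenyl would be the direct partner needed to part them. On these data alone, whether a carboxylic acid or a primary amine on this phenyl ring would move the number beyond the scatter also remains open.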